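The compounds below may be only part of what the source reports. "The series", "measured", "known", "first", "only" and "open" are said of these compounds alone.

Measured so far:
- compound 1, `COc1cccc(Oc2ccc3c(NCCCNCc4cc(F)ccc4OC)ccnc3c2)c1`: 14500 nM in a physicochemical assay for solubility, with a stated time of 18 h, at pH 7.4; a lower number here means a less soluble compound, a higher number a more soluble compound
- compound 2, `COc1cccc(CNCCCNc2ccnc3cc(Cc4cc(C)cc(C)c4)ccc23)c1O`: 4200 nM in this assay

Compound 2 gives the lower of the two numbers; the gap to compound 1 is beyond the usual scatter, so compound 2 is the less soluble of the pair on what is shown.

Compound 3, `COc1cccc(Oc2ccc3c(NCCCNCc4cccc(OC)c4O)ccnc3c2)c1`, is not yet measured in this assay. It differs from compound 2 in one place: 3-methoxyphenoxy in place of 3,5-dimethylbenzyl on an aromatic carbon. For the measured compounds named here, the entering group is the one that compound 1 also carries at this position.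

Going by the values given here, no measured step covers this exact exchange, so the expectation rests on the two values alone. With compound 1 giving 14500 nM and compound 2 giving 4200 nM, the exchange is expected to move the number upward, beyond the scatter, as a 2.9-fold higher number from compound 2 to compound 3 (0.46 log units; beyond the scatter). Compound 3 is thus estimated at 12000 nM, within a range from 4000 nM to 35000 nM.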

Compound 3, solubility: 14500 nM
For compound 3 the middle estimate is 1.2-fold (0.08 log units) below the measured one; the range from low to high includes it.
By their numbers in this assay, from the lowest: compound 2; then compounds 1 and 3 (each within the scatter of the next).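

In this assay, for the compounds shown here, 3-methoxyphenoxy in place of 3,5-dimethylbenzyl on the aromatic carbon gives a 3.5-fold higher number from compound 2 to compound 3 (0.54 log units; beyond the scatter) with the rest of the molecule held fixed, the first reading of this position alone. Going by these compounds alone, the exchange of 5-fluoro-2-methoxyphenyl for 2-hydroxy-3-methoxyphenyl on the saturated chain carbon gives no change at the digits printed from compound 1 to compound 3 (within the scatter) and so, of the two exchanges, only the one on the aromatic carbon moves the number beyond the scatter in these compounds. The data shown give no measured basis for explaining either step.

From the compounds shown here alone, whether the step on the aromatic carbon keeps its size with 5-fluoro-2-methoxyphenyl on the chain remains open. Also open, going by these compounds, is how a morpholine or a carboxylic acid at this aromatic carbon, or a longer chain on the amine side, would read in this assay here.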